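Removing the ester from a biaryl compound tested against the lipase

The compounds below may be only part of what the source reports. "The series", "measured", "known", "first", "only" and "open" are said of these compounds alone.

Compound 1, `CCOC(=O)c1cccc(-c2ccc(OCC)cc2)c1`, is the reference point of this small series. Going by the values given here, in an assay on COS-7 cells for inhibition of patatin-like phospholipase domain-containing protein 2 (Mus musculus), tested at 200 uM (a higher number here means more inhibition at the concentration tested (going by the name of the read-out), a lower number less inhibition), compound 1 gives 87%, the highest of the three numbers so far; compound 2, `CCOC(=O)c1cccc(-c2ccc([N+](=O)[O-])cc2)c1`, gives 63%, and compound 3, `CCOC(=O)c1cccc(-c2ccc(OCC)c(N)c2)c1`, gives 59%. Both measured steps away from compound 1 go downward: a number 24 percentage points lower from compound 1 to compound 2 (beyond the scatter) and a number 28 percentage points lower from compound 1 to compound 3 (beyond the scatter), each beyond the scatter.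

Compound 4, `CCOc1ccc(-c2ccccc2)cc1`, has not yet been measured. The change from compound 1 is hydrogen in place of ethoxycarbonyl on an aromatic carbon. Among the compounds with values here, neither measured step touches the ethoxycarbonyl, so no step bears directly on this change; the two that exist both show that altering the shared core of compound 1 cost inhibition. As far as these compounds go, on that basis a decrease in this assay beyond the scatter is expected, probably of at least comparable size, though its true extent is unknown. Compound 4 is therefore estimated at 45%, within a range of 15% to 75%, which means an expected step of a number 42 percentage points lower from compound 1 to compound 4 (beyond the scatter).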

Compound 4, a percentage reported as inhibition, at one concentration (the size of the read-out at that concentration, not a potency): 35%
Compound 4: the middle estimate sits 10 percentage points above what was measured, within the range that was stated.
By their numbers in this assay, from the lowest: compound 4; then compounds 3 and 2 (each within the scatter of the next); then compound 1.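

Replacing the ethoxycarbonyl with hydrogen on the aromatic carbon gives a number 52 percentage points lower from compound 1 to compound 4 (beyond the scatter), a large step where the two earlier steps were modest. Going by these compounds alone, this is the first measurement to show that the ethoxycarbonyl itself matters to the read-out in this assay, not only the substituents on the other ring. Inhibition does not vanish without the group, though, as compound 4 still gives 35%. Nothing measured here bears on what lies behind this loss.

As far as these compounds go, what the ester contributes remains open: a carboxylic acid or a primary amide at this place would show whether the carbonyl is enough without the ethoxy part. It is also unknown whether a longer chain on the ester would retain inhibition, or whether removing the ethoxycarbonyl would cost as much in compound 2 or compound 3.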